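Swapping 4-chlorophenyl for thiophen-2-yl at the assay limit

The compounds below may be only part of what the source reports. "The series", "measured", "known", "first", "only" and "open" are said of these compounds alone.

In a functional assay on MCF7 cells (Homo sapiens) for antiproliferative activity, read by MTT assay, with a stated time of 72 h (on this read-out higher numbers stand for weaker inhibition and lower numbers for stronger inhibition), compound 1 `CCCSc1nc(N/N=C(\C)c2ccc(O)cc2)c2nnn(Cc3ccccc3)c2n1` gives 21600 nM as a measured number. Compound 2 `CCCSc1nc(N/N=C/c2ccc(Cl)cc2)c2nnn(Cc3ccccc3)c2n1` has only > 64000 nM as its result, and this is a limit of the assay, not a number. Compound 3 `CCCSc1nc(N/N=C/c2cccs2)c2nnn(Cc3ccccc3)c2n1` keeps the shared core of compound 2 and takes thiophen-2-yl in place of 4-chlorophenyl on a carbon with a double bond to nitrogen, a change that reads thiophen-2-yl in place of 4-chlorophenyl on a carbon with a double bond to nitrogen and touches nothing else.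

Among the measured compounds shown here, one measured step bears on this, and only indirectly: an at least 2.9-fold higher number from compound 1 to compound 2 (0.47 log units; beyond the scatter) came with a different exchange, on a nitrogen on an aromatic ring. For the measured compounds named here, no measured step exchanges 4-chlorophenyl itself. Resting on compound 1 with 21600 nM as the only number in reach, the expectation is a modest move toward lower numbers, possibly none beyond the scatter. There is a real chance that compound 3 also stays at the limit. The estimated change is an at least 1.4-fold lower number from compound 2 to compound 3 (0.15 log units; that floor lies within the scatter) in this assay on this reasoning. For compound 3 the expected value is 45000 nM within an estimated range of 16000 nM to 64000 nM overall.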

Compound 3, half-maximal inhibitory concentration: > 64000 nM
Compound 3 ended at the assay's limit; the forecaster's own chance of this, stated with the estimate: 50%; middle value at least 1.4-fold (0.15 log units) away from the limit.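

In this assay, exchanging 4-chlorophenyl for thiophen-2-yl on a carbon with a double bond to nitrogen leaves the result at a limit of the assay rather than giving a number, so a five-membered aromatic ring with sulfur fares no differently here, as far as can be seen, from a six-membered one with chlorine. The step between these two compounds themselves cannot be read, because both end at the same place: the limit of > 64000 nM in this assay, at which 2 of the 3 values shown sit.

Among the compounds shown here, the comparison with the one measured number repeats what was seen for compound 2, with an at least 2.9-fold higher number from compound 1 to compound 3 (0.47 log units; beyond the scatter), so thiophen-2-yl, like 4-chlorophenyl, stays on the weaker side of compound 1.

On these data alone, how far compound 2 and compound 3 lie past the limit stays open, and so does any order between them. Also open, as far as these compounds go, is whether the hydroxyl or the methyl in the group that compound 1 carries accounts for its measured number, and whether an amine or a carboxylic acid on the ring at this carbon would bring a value back within the range of the assay.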